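This account rests on a few compounds, and the source may have more. Where it says the series, first, only, none or still open, it means among the compounds named here.

Measured compounds:

Compound 1, `CC1CCC(NC(=O)c2cc3c(Cl)cc(F)cc3[nH]2)CC1`, gives 77 mL.min-1.g-1 in an ADME assay on microsomes from liver (Mus musculus) for metabolic stability, read by LC-MS; on this read-out lower numbers stand for slow clearance and higher numbers for fast clearance.
Compound 2, `CC1CCC(NC(=O)c2cc3c(F)cc(Cl)cc3[nH]2)CC1`, gives 28 mL.min-1.g-1 in this assay.
Compound 3, `CC1CCC(NC(=O)c2cc3c(Cl)cccc3[nH]2)CC1`, gives 462 mL.min-1.g-1 in this assay.

Compound 1 and compound 2 are built from the same atoms joined differently; the difference between the two cores is not broken down here. Compound 2 has the lowest number of the three, with compound 1 nearest to it and compound 3 furthest from it. Compound 3 differs from compound 1 by one change, (hydrogen in place of fluoro on an aromatic carbon), and that change gave a 6.0-fold higher number from compound 1 to compound 3 (0.78 log units; beyond the scatter).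

Compound 4, `CC1CCC(NC(=O)c2cc3ccc(Cl)cc3[nH]2)CC1`, has not been measured in this assay. It differs from compound 2 by the same kind of change, (hydrogen in place of fluoro on an aromatic carbon). The place is not the same: in compound 1 the fluoro that leaves sits meta to a chloro group, meta to a fused ring and para to a fused ring, whereas in compound 2 it sits ortho to a fused ring, meta to a chloro group and meta to a fused ring.

Starting from compound 2 with 28 mL.min-1.g-1, the step to compound 4 is expected to be a 5.4-fold higher number from compound 2 to compound 4 (0.73 log units; beyond the scatter), which rests on the one earlier step of this kind, a 6.0-fold higher number from compound 1 to compound 3 (0.78 log units; beyond the scatter), set beside it, with wide bounds since the place differs and only one example is known. The value expected for compound 4 in this assay is 150 mL.min-1.g-1, within 55 mL.min-1.g-1 to 420 mL.min-1.g-1.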

Compound 4, intrinsic clearance in microsomes: 433 mL.min-1.g-1
The estimate for compound 4 lay 2.9-fold (0.46 log units) below the measured number, outside the stated range (above it).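

In this assay, hydrogen in place of fluoro on an aromatic carbon gave a 15-fold higher number from compound 2 to compound 4 (1.19 log units; beyond the scatter), and this step points the same way as the one already seen on the other core, with a size that cannot be told apart from it: the same change on two cores in this assay, a 6.0-fold higher number (0.78 log units; beyond the scatter) from compound 1 to compound 3 and a 15-fold higher number (1.19 log units; beyond the scatter) from compound 2 to compound 4, 2.6-fold (0.41 log units) apart, within the scatter of two such steps. So, across these two cores, the change carries over: losing the fluoro raises the number clearly each time, even though the fluoro sits in a different place in each core and the chloro group also sits elsewhere. This is only a pair of examples, however, so it does not show that the change would act the same way on a core without a chloro group, and it does not explain why the number rises.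

The compounds shown leave open whether a group other than fluoro in that same place, such as a nitrile or a methoxy group, would also keep the number well below that of the hydrogen compounds. They also leave open how the number would respond to a change away from the aromatic part, such as an amine or a carboxylic acid on the group carried by the amide nitrogen.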